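The compounds below may be only part of what the source reports. "The series", "measured", "known", "first", "only" and "open" are said of these compounds alone.

Measured so far:
compound 1 `CC(=O)O[C@H]1C=CC(=O)O[C@H]1[C@H]1OC(=O)O[C@@H]1c1ccccc1` — > 40000 nM
compound 2 `CC(=O)O[C@H]1C=CC(=O)O[C@@H]1c1nc(/C=C/c2ccccc2)oc1-c1ccccc1` — 24600 nM

Both compounds share a core carrying an acetate and an unsaturated lactone. In a functional assay on SMMC-7721 cells (Homo sapiens) for cytotoxicity, read by MTT assay, with a stated time of 48 h (on this read-out higher numbers stand for weaker inhibition and lower numbers for stronger inhibition), compound 1 gives > 40000 nM; this is a limit of the assay, not a number, and it is the limit described by the limit of > 40000 nM in this assay, at which 1 of the 2 values shown sits. In this assay, among the compounds with values here, compound 2 gives 24600 nM, which is the only numerical value shown, so compound 2 stands alone as the one compound with a measured number. Compound 3 `CC(=O)O[C@H]1C=CC(=O)O[C@@H]1c1nc(-c2ccccc2)oc1-c1ccccc1` differs from compound 2 by phenyl in place of 2-phenylethenyl on an aromatic carbon. Within the data shown here, no measured step between compounds tells how such a change plays out here. The expectation is a step from compound 2 to compound 3 of a 1.2-fold higher number from compound 2 to compound 3 (0.09 log units; within the scatter), not beyond the usual scatter. Compound 3 is therefore estimated at 30000 nM, within a range from 12000 nM to 80000 nM.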

Compound 3, half-maximal inhibitory concentration: 15700 nM
The estimate for compound 3 lay 1.9-fold (0.28 log units) above the measured number; the range from low to high includes it.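

In this assay, putting phenyl in place of 2-phenylethenyl on this aromatic carbon of the five-membered aromatic ring gives a 1.6-fold lower number from compound 2 to compound 3 (0.20 log units; within the scatter). Within the data shown here, this is the first measured step at this position, and it shows that the double bond outside the aromatic rings can go, with the six-membered aromatic ring kept, without the number moving beyond the usual scatter. Nothing measured here gives a reason for this result.

Going by these compounds, whether a methyl group or an amine on this same carbon, or a chlorine on the phenyl group, would shift the number beyond the scatter remains open. Among these compounds, compound 1 gives > 40000 nM, which is a limit of the assay and not a number, so no step to it can be read.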